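Swapping sulfur for selenium on the isoxazole core

A few compounds are considered here, and "the series" means these few. Any claim that something is new, unique, unknown or untested is made for them only; others in the source may bear on it.

Of the compounds shown here, three of one family have been tested in a functional assay on HT-29 cells (Homo sapiens) for cytotoxicity, read by MTT assay, with a stated time of 72 h; on this read-out higher numbers stand for weaker inhibition of growth and lower numbers for stronger inhibition of growth. Compound 1 `C[Se]/C(=N\C(=O)c1cc2ccccc2s1)NC(=O)c1cc2ccccc2s1` gives 5620 nM in this assay, and compound 3 `CS/C(=N\C(=O)c1cc2ccccc2s1)NC(=O)c1cc2ccccc2s1` gives 16800 nM. The only difference between them is the group on the carbon with a double bond to nitrogen, and the change a 3.0-fold higher number from compound 1 to compound 3 (0.48 log units; beyond the scatter) shows the selenium-bearing compound 1 with the lower number. Compound 2 `CS/C(=N\C(=O)c1ccno1)NC(=O)c1ccno1` carries the same methylsulfanyl group on a smaller core, and in this assay compound 2 reaches only a limit, > 100000 nM, so no number is known for it; it sits at the limit of > 100000 nM in this assay, at which 1 of the 3 values shown sits, the top of the range shown.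

Compound 4 `O=C(/N=C(/NC(=O)c1ccno1)[Se]Cc1ccccc1)c1ccno1` keeps the core of compound 2 but differs by a group of 8 heavy atoms (7 carbon, 1 selenium; one six-membered aromatic ring of carbon only) in place of a group of 2 heavy atoms (1 carbon, 1 sulfur; no ring), on a carbon with a double bond to nitrogen. For the measured compounds named here, the one measured step that bears on this is the one from compound 1 to compound 3, where a methyl on sulfur in place of a methyl on selenium raised the number by a modest amount. Going by the values given here, compound 4 goes the other way, sulfur to selenium, so a lower number is expected, though the added benzyl group has no measured precedent here and compound 2 itself is only a limit. The expected step for compound 4 is an at least 3.3-fold lower number from compound 2 to compound 4 (0.52 log units; beyond the scatter). Compound 4 is therefore estimated at 30000 nM, within a range from 5000 nM to 150000 nM.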

Compound 4, concentration for 50% growth inhibition: 6820 nM
Compound 4: middle estimate off by 4.4-fold (0.64 log units), on the high side, within the range that was stated.
By their numbers in this assay, from the lowest: compounds 1 and 4 (each within the scatter of the next); then compound 3. At a limit, above all of these: compound 2.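

On the core of compound 2, the carbon with a double bond to nitrogen, whose other neighbours are amide-type nitrogens, can carry a much larger group than methylsulfanyl and still give a measured value in this assay: the change gives an at least 14-fold lower number from compound 2 to compound 4 (1.16 log units; beyond the scatter). The size of that step is only a bound, since its starting point is a limit: the limit of > 100000 nM in this assay, at which 1 of the 4 values shown sits.

For the compounds shown here, changing the atom alone, on a different core, gave a modest step of the opposite direction, a 3.0-fold higher number from compound 1 to compound 3 (0.48 log units; beyond the scatter), so the new step is the first large one seen at this position.

The new step changes the atom and the group it carries at the same time, so the compounds shown cannot divide the effect between selenium and the added benzyl group; a methyl on selenium or a benzyl on sulfur on this same core would separate them. From the compounds shown here alone, it also remains open whether this position accepts other kinds of group, such as an amine or a carboxylic acid at the end of a longer chain.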